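Notes on the step from compound 1 to compound 4

The source may hold more compounds than are shown below. What is called first, only, known or untested is meant among the compounds shown, and "the series" means these compounds.

The series shares the core of compound 1 `Cc1ccc(S(=O)(=O)Nc2ccc3c(c2)C(=O)N(Cc2ccccc2)C3=O)cc1`. In an assay on isolated protein for inhibition of lactase/phlorizin hydrolase (Rattus norvegicus), read by colorimetric assay (a lower number here means a stronger inhibitor, a higher number a weaker inhibitor), compound 1 gives > 200000 nM, which is a limit of the assay and not a number. Compound 2 `O=C1c2ccc([N+](=O)[O-])cc2C(=O)N1CCNc1ccccc1` gives > 200000 nM in this assay, also a limit. Compound 3 `Nc1ccc2c(c1)C(=O)N(CCNc1ccccc1)C2=O` gives > 200000 nM in this assay, again a limit. For the measured compounds named here, the one change between measured compounds, a step that the two limits leave unreadable from compound 2 to compound 3, cannot be read because of the limit of > 200000 nM in this assay, at which 3 of the 3 values shown sit. Compound 1 therefore stands at the same limit as the other two values shown, and nothing separates it from them.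

Compound 4 `Cc1ccc(S(=O)(=O)Nc2ccc3c(c2)C(=O)N(CCNc2ccc(O)c(O)c2)C3=O)cc1` differs from compound 1 by a group of 10 heavy atoms (7 carbon, 1 nitrogen, 2 oxygen; one six-membered aromatic ring of carbon only) in place of a group of 6 heavy atoms (6 carbon; one six-membered aromatic ring of carbon only), on a saturated chain carbon bound to an amide-type nitrogen in a ring. Going by the values given here, no measured step bears on this change: the step from compound 2 to compound 3 concerns a different part of the core and is unreadable anyway. With every value at the limit, neither a direction nor a size beyond the scatter can be expected. Compound 4 is estimated at 200000 nM, between 50000 nM and 600000 nM, and the expected step of a number no higher from compound 1 to compound 4 (the limit leaves the size open) is accordingly one the data cannot support in either direction.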

Compound 4, half-maximal inhibitory concentration: 66600 nM
Compound 4: middle estimate off by 3.0-fold (0.48 log units), on the high side; measured number inside the range.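

For the compounds shown here, the change on a saturated chain carbon bound to an amide-type nitrogen in a ring gives the first readable step, an at least 3.0-fold lower number from compound 1 to compound 4 (0.47 log units; beyond the scatter). This place therefore tolerates a larger group, and the entering group, with hydrogen-bond donors and acceptors where the phenyl has none, brings a value inside the range of this assay. The step can be stated only as a minimum because compound 1 stands at a limit and not at a number: the limit of > 200000 nM in this assay, at which 3 of the 4 values shown sit.

The entering group differs from phenyl in its chain, its nitrogen and its two oxygens together, so the compounds shown do not separate the share of each in the step. Going by these compounds, how a methoxy group or a carboxylic acid in place of those oxygens would read also stays open.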